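Will compound 3 hold up in liver microsomes?

The source may report more compounds than this note shows. Statements on the series, on what has been measured and on what is new or still open speak of the compounds shown alone.

Compound 1 `O=C(NCc1ccc(S(=O)(=O)c2cccc(F)c2)cc1)c1cc2cnccc2[nH]1`: 79%
Compound 2 `O=C(NCc1ccc(S(=O)(=O)c2cccc(C(F)(F)F)c2)cc1)c1cc2cnccc2[nH]1`: 81%

In an ADME assay on microsomes from liver (Homo sapiens) for metabolic stability, read by LC-MS, with a stated time of 30 min, tested at 1 uM (a higher number here means that more of the compound is left, a lower number that less of the compound is left), compound 2 gives 81%, which lies within the usual scatter of compound 1 at 79%. With only these two numbers, the compounds cannot be told apart.

The next compound is compound 3 `O=C(NCc1ccc(S(=O)(=O)c2cc(F)cc(F)c2)cc1)c1cc2cnccc2[nH]1`, which keeps the shared core but carries a different group on the sulfonyl sulfur: 3,5-difluorophenyl in place of 3-(trifluoromethyl)phenyl on a sulfonyl sulfur. In other words, 3,5-difluorophenyl stands in place of 3-(trifluoromethyl)phenyl.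

Among the measured compounds shown here, only one measured step bears on this change. It put trifluoromethyl in place of fluoro on an aromatic carbon and gave a number 2 percentage points higher from compound 1 to compound 2 (within the scatter). That is a small step, and it is a single case. For the measured compounds named here, no measured compound yet carries the 3,5-difluorophenyl group, so this evidence is indirect. On that basis, no step beyond the scatter is expected in this assay. The estimated change is a number 3 percentage points lower from compound 2 to compound 3 (within the scatter). Compound 3 is expected to give 78%, with an estimated range of 66% to 88%.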

Compound 3, percent of the compound remaining: 82%
Compound 3: middle estimate off by 4 percentage points, on the low side; low and high end bracket the measured number.
By their numbers in this assay, from the lowest: compounds 1, 2 and 3 (each within the scatter of the next).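

In this assay, 3,5-difluorophenyl in place of 3-(trifluoromethyl)phenyl on a sulfonyl sulfur gives a number 1 percentage points higher from compound 2 to compound 3 (within the scatter), and fluoro in place of hydrogen on an aromatic carbon gives a number 3 percentage points higher from compound 1 to compound 3 (within the scatter). Compounds 1, 2 and 3 therefore cannot be told apart in this assay, so the sulfonyl position now has three different fluorinated aromatic groups that read the same, and a second fluoro on the ring makes no measurable difference here. No measured evidence is available to explain why these groups read alike.

As far as these compounds go, all three compounds carry a fluorinated six-membered aromatic ring on the sulfonyl sulfur, so it remains open whether plain phenyl, or a ring bearing an amine or a carboxylic acid, would stay within the same scatter. From the compounds shown here alone, it is also open whether a saturated group such as cyclohexyl, placed on the same sulfur, would leave as much of the compound after incubation with liver microsomes.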